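A few compounds are considered here, and "the series" means these few. Any claim that something is new, unique, unknown or untested is made for them only; others in the source may bear on it.

Compound 3 `CCc1cccc(C)c1-n1nncc1CN1C(=O)C2(C(C#N)=C(N)Oc3c(N)cc4nc5ccccc5nc4c32)c2ccccc21` sits at the edge of what the measurement can report: in an ADME assay on HUVEC cells (Homo sapiens) for antiproliferative activity, read by MTT assay, with a stated time of 48 h (a lower number here means a stronger inhibitor, a higher number a weaker inhibitor), compound 3 gives > 50000 nM, a limit of the assay rather than a number. In this assay compound 2 `Cc1ccc(-n2nncc2CN2C(=O)C3(C(C#N)=C(N)Oc4c(N)cc5nc6ccccc6nc5c43)c3ccccc32)cc1C` gives > 50000 nM, also a limit. In this assay compound 1 `N#CC1=C(N)Oc2c(N)cc3nc4ccccc4nc3c2C12C(=O)N(Cc1cnnn1-c1ccccc1Br)c1ccccc12` gives 34200 nM. The steps of an at least 1.4-fold higher number from compound 1 to compound 2 (0.16 log units; that floor lies within the scatter) and an at least 1.4-fold higher number from compound 1 to compound 3 (0.16 log units; that floor lies within the scatter) rest on that limit (the limit of > 50000 nM in this assay, at which 2 of the 3 values shown sit), while a step that the two limits leave unreadable from compound 2 to compound 3 offers nothing further. Compound 4 `N#CC1=C(N)Oc2c(N)cc3nc4ccccc4nc3c2C12C(=O)N(Cc1cnnn1-c1c(Cl)cc(Cl)cc1Cl)c1ccccc12` differs from compound 3 by 2,4,6-trichlorophenyl in place of 2-ethyl-6-methylphenyl on an aromatic nitrogen. Only limits bound the two measured changes at this position, so no shift beyond the scatter is expected in this assay, and a further limit is the likelier outcome. Compound 4 is therefore estimated at 50000 nM, between 20000 nM and 120000 nM, a step of a number no higher from compound 3 to compound 4 (the limit leaves the size open).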

Compound 4, half-maximal inhibitory concentration: 18300 nM
Compound 4: the middle estimate sits 2.7-fold (0.44 log units) above what was measured; the measured number lies below the stated range.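

In this assay, the group on this aromatic nitrogen can shift the reading beyond the scatter, as 2,4,6-trichlorophenyl gives an at least 2.7-fold lower number from compound 3 to compound 4 (0.43 log units; beyond the scatter) and an at least 2.7-fold lower number from compound 2 to compound 4 (0.43 log units; beyond the scatter). Both steps are floors that rest on a limit: the limit of > 50000 nM in this assay, at which 2 of the 4 values shown sit. Set against the 2-bromophenyl group, the same change gives only a 1.9-fold lower number from compound 1 to compound 4 (0.27 log units; within the scatter), so the two halogen-bearing compounds are not separated.

Which of the three chlorines matters stays open. So does how a phenyl ring carrying an amine or a carboxylic acid would read here.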